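Dropping the alkene methyl on a cinnamamide-type side chain

The source may hold more compounds than are shown below. What is called first, only, known or untested is meant among the compounds shown, and "the series" means these compounds.

Measured compounds:
- compound 1, `C/C(=C\C(=O)Nc1ccc2nc(N3CCC(O)CC3)nc(C)c2c1)c1ccc(Cl)cc1`: 227 nM
- compound 2, `C/C(=C\C(=O)Nc1ccc2nc(N3CCC(O)(C4CC4)CC3)nc(C)c2c1)c1ccc(Cl)cc1`: 340 nM
- compound 3, `Cc1nc(N2CCC(N3CCNC3=O)CC2)nc2ccc(NC(=O)/C=C/c3ccc(OC(F)(F)F)cc3)cc12`: 31 nM

All three were tested in a functional assay on CHO-K1 cells for antagonist activity at melanin-concentrating hormone receptor 1 (Homo sapiens), read by inositol phosphate accumulation, with stated times of 10 min and 45 min; a lower number here means a stronger inhibitor, a higher number a weaker inhibitor. Going by the values given here, compound 1 stands second highest of the three numbers; its nearest neighbour is compound 2, and the one step that is known, a 1.5-fold higher number from compound 1 to compound 2 (0.18 log units; within the scatter), lies within the scatter. Compound 3, which carries a different side chain and a different group on the saturated ring, gives 31 nM, a lower number than compound 1 and beyond the scatter.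

Compound 4, `Cc1nc(N2CCC(O)CC2)nc2ccc(NC(=O)/C=C/c3ccc(Cl)cc3)cc12`, is compound 1 with one change: 2-(4-chlorophenyl)ethenyl in place of 2-(4-chlorophenyl)prop-1-en-1-yl on a carbonyl carbon. Among the compounds with values here, no measured pair differs in just this way, so nothing known bears directly on it. Compound 3 carries the same 2-arylethenyl arrangement, but it differs in two further places, so its value 31 nM shows only that a side chain of this kind can go with a low number.

Compound 4 is therefore expected to land near compound 1 or somewhat lower, a step of a 1.9-fold lower number from compound 1 to compound 4 (0.28 log units; within the scatter), with an estimate of 120 nM and a range from 30 nM to 500 nM.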

Compound 4, half-maximal inhibitory concentration: 73 nM
The estimate for compound 4 lay 1.6-fold (0.22 log units) above the measured number, and the stated range covers the measured number.
By their numbers in this assay, from the lowest: compound 3; then compound 4; then compounds 1 and 2 (each within the scatter of the next).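

The side chain on the carbonyl carbon proves sensitive to a very small edit: in this assay, 2-(4-chlorophenyl)ethenyl in place of 2-(4-chlorophenyl)prop-1-en-1-yl gives a 3.1-fold lower number from compound 1 to compound 4 (0.49 log units; beyond the scatter). Going by these compounds alone, this is the first direct reading at this position, since compound 3 differs from compound 1 in several places and the only earlier single change, on the saturated ring, stayed within the scatter. Why the number falls cannot be said from these results, as no measurement addresses the cause.

Going by these compounds, it remains open whether a fluorine or an ethyl group on the same alkene carbon would give a number closer to that of the methyl-bearing side chain or of the unsubstituted one. Within the data shown here, it also remains open whether the step would repeat with another group on the saturated ring, such as the one in compound 3.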